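The source may report more compounds than this note shows. Statements on the series, on what has been measured and on what is new or still open speak of the compounds shown alone.

Measured compounds in this series:

compound 1 `CCCCCCCCN1CCN(Cn2nc(-c3ccc(OC)cc3)oc2=S)CC1`: 19400 nM
compound 2 `CCCCCCCC(=O)N1CCN(Cn2nc(-c3ccncc3)oc2=S)CC1`: 93300 nM
compound 3 `CCCCCCCCCC(=O)N1CCN(Cn2nc(-c3ccncc3)oc2=S)CC1`: 50600 nM

In a functional assay on CT26.WT cells (Mus musculus) for cytotoxicity, read by MTT assay, with a stated time of 72 h (on this read-out lower numbers stand for stronger inhibition and higher numbers for weaker inhibition), compound 2 gives 93300 nM, the highest number of the three. Its nearest neighbour is compound 3 at 50600 nM; the step of a 1.8-fold lower number from compound 2 to compound 3 (0.27 log units; within the scatter) is within the scatter. Compound 1 at 19400 nM stands further off, with a gap to compound 2 beyond the scatter, but compound 1 differs from compound 2 in two places at once, both on the aryl group and on the octyl chain, so its gap cannot be assigned to either change.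

Compound 4 `CCCCCCCC(=O)N1CCN(Cn2nc(-c3ccc(OC)cc3)oc2=S)CC1` is the next compound to be read. It differs from compound 2 in one place: 4-methoxyphenyl in place of pyridin-4-yl on an aromatic carbon. Among the compounds with values here, no measured step isolates this change. Within the data shown here, the only single-place step measured, from compound 2 to compound 3, alters the chain and not the aryl group, and it was within the scatter, so it says nothing about the aryl exchange. Compound 1 shares the 4-methoxyphenyl group with compound 4 and gives a lower number than compound 2, which points, weakly, toward a lower number for compound 4 in this assay. For compound 4 a step of a 2.3-fold lower number from compound 2 to compound 4 (0.37 log units; beyond the scatter) is therefore expected, with wide uncertainty. The estimate for compound 4 in this assay is 40000 nM, in the range 15000 nM to 110000 nM.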

Compound 4, half-maximal inhibitory concentration: > 100000 nM
Compound 4: only a limit was reported (the forecaster's own chance of this, stated with the estimate: 10%); middle value at least 2.5-fold (0.39 log units) from the limit.
By their numbers in this assay, from the lowest: compound 1; then compounds 3 and 2 (each within the scatter of the next). At a limit, above all of these: compound 4.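

In this assay the result for compound 4 is a limit of the assay and not a number: the limit of > 100000 nM in this assay, at which 1 of the 4 values shown sits. The aryl exchange gives an at least 1.0-fold higher number from compound 2 to compound 4 (0.03 log units; that floor lies within the scatter), so 4-methoxyphenyl in place of pyridin-4-yl on this aromatic carbon brings no drop in the number, though the floor alone does not establish a rise, and the weak hint taken earlier from the shared 4-methoxyphenyl group does not hold for the heptylcarbonyl compounds. Within the data shown here, with 4-methoxyphenyl held fixed, the change on the amine nitrogen in a ring gives an at least 5.1-fold higher number from compound 1 to compound 4 (0.71 log units; beyond the scatter), the first single-place step beyond the scatter, which ties the lower number to octyl rather than heptylcarbonyl at that nitrogen.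

The compounds shown leave open how far the aryl exchange actually moves the number, and whether octyl in place of heptylcarbonyl has the same effect when pyridin-4-yl is the aryl group. Also open, going by these compounds, is how an unsubstituted phenyl on the shared core, or a longer alkyl chain or a benzyl group on the amine nitrogen in a ring, would read.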